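Replacing a pyridinyl sulfoxide with a trifluoromethoxyphenyl sulfoxide

The source may hold more compounds than are shown below. What is called first, only, known or untested is meant among the compounds shown, and "the series" means these compounds.

Compound 2 `CC(O)(C[S+]([O-])c1ccccn1)C(=O)Nc1ccc([N+](=O)[O-])cc1C(F)(F)F` belongs to a pair sharing one core. In a functional assay on DU-145 cells (Homo sapiens) for antiproliferative activity (a lower number here means a stronger inhibitor, a higher number a weaker inhibitor), compound 2 gives only a limit, > 100000 nM, and no number. Compound 1 `CC(O)(C[S+]([O-])c1ccc(C(F)(F)F)cn1)C(=O)Nc1ccc([N+](=O)[O-])cc1C(F)(F)F` gives in this assay > 100000 nM; > 100000 nM (2 entries). Compound 3 `CC(O)(C[S+]([O-])c1ccc(OC(F)(F)F)cc1)C(=O)Nc1ccc([N+](=O)[O-])cc1C(F)(F)F` differs from compound 2 by 4-(trifluoromethoxy)phenyl in place of pyridin-2-yl on a sulfur, a 4-(trifluoromethoxy)phenyl in place of pyridin-2-yl on a sulfur. Going by the values given here, no measured step exists here; the expected step that the limit leaves unreadable from compound 2 to compound 3 is small, with compound 3 expected to stay near the limit because compound 2 shows > 100000 nM. Compound 3 is estimated at 150000 nM, between 30000 nM and 1000000 nM.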

Compound 3, half-maximal inhibitory concentration: > 100000 nM
Compound 3: only a limit was reported; the forecaster's own chance of this, stated with the estimate: 80%; the middle value lies beyond the limit too.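

In this assay compound 3 gives > 100000 nM, a limit and not a number. Going by these compounds alone, compound 2 also gives only a limit, so no step between compound 2 and compound 3 can be read. The compounds shown leave open whether the group on the sulfur changes activity in this assay at all.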